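Series notes: the 2-hydroxyphenyl analogue, compound 3

The compounds below may be only part of what the source reports. "The series", "measured", "known", "first", "only" and "open" are said of these compounds alone.

Compound 1 `Fc1ccc(Nc2nc(-c3cccc(F)c3)nc3ccc(F)cc23)cc1` was run in a functional assay on U-937 cells (Homo sapiens) for cytotoxicity, read by MTT assay, with a stated time of 48 h; on this read-out lower numbers stand for stronger inhibition and higher numbers for weaker inhibition. In this assay compound 1 gives > 50000 nM, which is a limit of the assay and not a number. Compound 2 `Fc1cccc(-c2nc(Nc3cccc(Cl)c3)c3cc(F)ccc3n2)c1` carries 3-chlorophenyl in place of 4-fluorophenyl on a nitrogen on an aromatic ring. In this assay compound 2 gives > 50000 nM, again a limit of the assay. The step that the two limits leave unreadable from compound 1 to compound 2 cannot be sized, since both values sit at the limit of > 50000 nM in this assay, at which 2 of the 2 values shown sit. Compound 2 thus stands at the limit, with no number to rank it.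

Compound 3 `Oc1ccccc1Nc1nc(-c2cccc(F)c2)nc2ccc(F)cc12` is not yet measured. It differs from compound 2 by 2-hydroxyphenyl in place of 3-chlorophenyl on a nitrogen on an aromatic ring. Within the data shown here, the only measured step, from compound 1 to compound 2, is unreadable, so no step size can be carried over; the 2-hydroxyphenyl group brings one hydrogen-bond donor and one hydrogen-bond acceptor where 3-chlorophenyl had none, but no measured value shows what that does in this assay. The step from compound 2 to compound 3 is expected to be a number no higher from compound 2 to compound 3 (the limit leaves the size open), meaning nothing beyond the scatter. Compound 3 is expected to give 50000 nM in this assay, with a range from 15000 nM to 200000 nM, most likely reported as a limit again.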

Compound 3, half-maximal inhibitory concentration: 46300 nM
The estimate for compound 3 lay 1.1-fold (0.03 log units) above the measured number, and the stated range covers the measured number.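

In this assay, among these compounds, compound 3 gives 46300 nM, the only number among the three values shown and the first reading at this position, on a nitrogen on an aromatic ring, that is not a limit of the assay. Among the compounds shown here, the readable floors are an at least 1.0-fold lower number from compound 2 to compound 3 (0.03 log units; that floor lies within the scatter) and an at least 1.0-fold lower number from compound 1 to compound 3 (0.03 log units; that floor lies within the scatter), so 2-hydroxyphenyl shows no gain beyond the scatter over either 3-chlorophenyl or 4-fluorophenyl, and it shows only that this change can yield a number close to where the other two compounds stop being measurable. The true size of both steps stays open because the other two values are limits of the assay, not numbers: the limit of > 50000 nM in this assay, at which 2 of the 3 values shown sit.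

The compounds shown do not tell whether the hydrogen-bond donor and acceptor counted on 2-hydroxyphenyl account for the number in compound 3, since no compound separates them from the rest of the group. They also leave open whether 2-aminophenyl or 2-carboxyphenyl on the same nitrogen, with the rest of the core of compound 3 unchanged, would give a number clearly beyond the scatter of compound 3.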